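A Methoxy Group Added to the Carbamate Benzyl Ring

The compounds below may be only part of what the source reports. "The series", "measured", "known", "first", "only" and "open" are said of these compounds alone.

For the measured compounds named here, compound 2 `O=C(OCc1ccccc1)N(c1ccccc1)C1CN2CCC1CC2` gives 150 nM in an assay on CHO cells for displacement of a labelled ligand from muscarinic acetylcholine receptor M5 (Homo sapiens), read by scintillation counting, with a stated time of 2 h (a lower number here means a stronger inhibitor, a higher number a weaker inhibitor), the higher of the two numbers measured so far. Compound 1 `Cc1ccc(COC(=O)N(c2ccccc2)C2CN3CCC2CC3)cc1F`, which carries 3-fluoro-4-methylphenyl instead of phenyl on the saturated chain carbon bound to the oxygen next to the carbonyl, gives 30 nM in this assay; the step of a 5.0-fold higher number from compound 1 to compound 2 (0.70 log units; beyond the scatter) shows that substitution on this ring lowers the number. Compound 3 `COc1ccc(COC(=O)N(c2ccccc2)C2CN3CCC2CC3)cc1` differs from compound 2 by methoxy in place of hydrogen on an aromatic carbon. Going by the values given here, because a 5.0-fold higher number from compound 1 to compound 2 (0.70 log units; beyond the scatter) is the only step bearing on this change, a modest lowering is expected, estimated as a 2.3-fold lower number from compound 2 to compound 3 (0.36 log units; beyond the scatter). Compound 3 is therefore expected to give 65 nM, within 25 nM to 170 nM.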

Compound 3, inhibition constant: 470 nM
Beside the measured number, compound 3's estimate is 7.2-fold (0.86 log units) below it; measured number outside the range, above it.
By their numbers in this assay, from the lowest: compound 1; then compound 2; then compound 3.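

In this assay, substitution on this ring does not by itself lower the number: methoxy, para to a large group, gives a 3.1-fold higher number from compound 2 to compound 3 (0.50 log units; beyond the scatter), a change opposite in direction to the one seen with 3-fluoro-4-methylphenyl. Against that group, 4-methoxyphenyl gives a 16-fold higher number from compound 1 to compound 3 (1.19 log units; beyond the scatter), so the outcome depends on which group the ring carries. Nothing measured here explains this reversal. From the compounds shown here alone, how 4-methylphenyl, 3-fluorophenyl or a ring bearing an amine or a carboxylic acid would read remains open.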